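Flipping One Ring Stereocentre in a Glycoside Series

A few compounds are considered here, and "the series" means these few. Any claim that something is new, unique, unknown or untested is made for them only; others in the source may bear on it.

Of the compounds shown here, three on a shared sugar-based core have been measured so far. Compound 1 `CO[C@H]1O[C@H](COc2ccc(OC3CCCCC3)cc2)[C@@H](O)[C@H](O)[C@H]1Oc1ccc(C(C)C)cc1` gives 25000 nM in a functional assay on MDA-MB-231 cells (Homo sapiens) for cytotoxicity, read by MTT assay, with a stated time of 48 h; on this read-out higher numbers stand for an effect only at larger amounts of compound and lower numbers for an effect already at smaller amounts. Compound 2 `CO[C@H]1O[C@H](COc2ccc(OC3CCCCC3)cc2)[C@@H](O)[C@H](O)[C@H]1Oc1ccc(OC2CCCCC2)cc1` gives 20000 nM in this assay, and compound 3 `CO[C@H]1O[C@H](COc2ccc(C3CCCCC3)cc2)[C@@H](O)[C@H](O)[C@H]1Oc1ccc(OC2CCCCC2)cc1` gives 14000 nM in this assay. Compound 2 stands second highest of the three numbers; its nearest neighbour is compound 1 and its furthest is compound 3, and both gaps lie within the scatter, so no order among the three can be read from them. The two measured steps, a 1.3-fold lower number from compound 1 to compound 2 (0.10 log units; within the scatter) and a 1.4-fold lower number from compound 2 to compound 3 (0.15 log units; within the scatter), each exchanged a group on an aromatic carbon and each stayed within the scatter.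

Compound 4 `CO[C@@H]1O[C@H](COc2ccc(OC3CCCCC3)cc2)[C@@H](O)[C@H](O)[C@H]1Oc1ccc(OC2CCCCC2)cc1` differs from compound 2 only in configuration: the two compounds have the same atoms and bonds and differ only in configuration as drawn: 1 of 5 stereo elements differ; a stereocentre at a saturated ring carbon is drawn S in compound 2 and R in compound 4. Among the measured compounds shown here, no measured step touches a stereocentre, so nothing measured here bears directly on this change; the only guidance is that every step seen on this core has been small. For compound 4 the value in this assay is therefore expected to be 20000 nM, within a range from 8000 nM to 50000 nM. The step from compound 2 is estimated as no change at the digits printed from compound 2 to compound 4 (within the scatter), that is, no step beyond the scatter in either direction.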

Compound 4, half-maximal effective concentration: 26000 nM
Estimate against measurement, compound 4: 1.3-fold (0.11 log units) below; the range from low to high includes it.
By their numbers in this assay, from the lowest: compounds 3, 2, 1 and 4 (each within the scatter of the next).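

Among the compounds shown here, the stereocentre at this saturated ring carbon is the first place on the shared core where configuration rather than a group on an aromatic carbon is changed, and in this assay the inversion gives a 1.3-fold higher number from compound 2 to compound 4 (0.11 log units; within the scatter). The pair reads this one centre alone, with no group entering or leaving: the fact that compounds 2 and 4 differ only in the configuration as drawn On the background of compound 2, the change from S to R therefore joins the exchanges on aromatic carbons as a step that stays within the scatter, and no preference for either configuration can be read from this pair.

The R configuration is shown only with the two cyclohexyloxy groups of compound 4, so it remains open whether the same inversion would stay as small with the isopropyl group of compound 1 or the cyclohexyl group of compound 3, and what inversion of any of the other four stereo elements would do. Also open, from the compounds shown here alone, is whether an amine or a carboxylic acid on the aromatic carbons would give a step beyond the scatter on this core.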